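The source may hold more compounds than are shown below. What is called first, only, known or untested is meant among the compounds shown, and "the series" means these compounds.

Within the data shown here, in a functional assay on HOS-TE85 cells (Homo sapiens) for inhibition, read by CCK-8 assay, with a stated time of 72 h (a higher number here means a weaker inhibitor, a lower number a stronger inhibitor), compound 2 `COc1ccc(F)cc1N1C(=O)CSC1c1cccc(C(=O)NCCCCn2cccn2)c1` gives 97.3 nM, the only actual number so far. Compound 1 `COc1ccc(OC)c(N2C(=O)CSC2c2cccc(C(=O)NCCCCc3ccccc3)c2)c1`, whose chain also ends in phenyl, stands at > 1000 nM, which is a limit of the assay and not a number. Compound 3 `COc1ccc(F)cc1N1C(=O)CSC1c1cccc(C(=O)NCCCCc2ccccc2)c1` departs from compound 2 by phenyl in place of 1H-pyrazol-1-yl on a saturated chain carbon, four bonds along the chain from an amide-type nitrogen. With compound 1 at > 1000 nM, a weakening beyond the scatter is expected in this assay. The expected change is a 5.1-fold higher number from compound 2 to compound 3 (0.71 log units; beyond the scatter). Compound 3 is estimated at 500 nM, with an expected range of 150 nM to 2000 nM.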

Compound 3, half-maximal inhibitory concentration: 8.8 nM
Estimate against measurement, compound 3: 57-fold (1.75 log units) above; the measured number lies below the stated range.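

In this assay, phenyl at this chain end proves far better than 1H-pyrazol-1-yl, with an 11-fold lower number from compound 2 to compound 3 (1.04 log units; beyond the scatter), so the phenyl end of compound 1 does not by itself account for its reading. Fluoro in place of methoxy on an aromatic carbon then carries an at least 110-fold lower number from compound 1 to compound 3 (2.05 log units; beyond the scatter), which makes that single change decisive with phenyl at the chain end. Compound 1 stands at a limit of the assay and not at a number: the limit of > 1000 nM in this assay, at which 1 of the 3 values shown sits.

Only phenyl and 1H-pyrazol-1-yl are shown at this chain end, so how an amine, a carboxylic acid or a longer chain would read stays open. As far as these compounds go, whether chloro could stand in for fluoro on that aromatic carbon also stays open.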